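The compounds below may be only part of what the source reports. "The series", "measured", "known", "first", "only" and "open" are said of these compounds alone.

In a functional assay on MCF7 cells (Homo sapiens) for antiproliferative activity, read by CellTiter-Glo, with a stated time of 5 days (on this read-out lower numbers stand for stronger inhibition and higher numbers for weaker inhibition), compound 1 (`CC1=C(c2cccc(O)c2)[C@H](c2ccc(OC[C@H](C)N3CC[C@@H](C)C3)cc2)Oc2ccc(O)cc21`) gives 0.1 nM and compound 2 (`CC1=C(c2ccc(S(C)(=O)=O)cc2)C(c2ccc(OC[C@H](C)N3CC[C@@H](C)C3)cc2)Oc2ccc(O)cc21`) gives 27 nM, while compound 3 (`CC1=C(c2ccc(C#N)cc2)C(c2ccc(OC[C@H](C)N3CC[C@@H](C)C3)cc2)Oc2ccc(O)cc21`) gives 10 nM as the second highest of the three numbers. Compound 4 (`CC1=C(c2cccc(S(C)(=O)=O)c2)C(c2ccc(OC[C@H](C)N3CC[C@@H](C)C3)cc2)Oc2ccc(O)cc21`) has 3-(methylsulfonyl)phenyl in place of 4-cyanophenyl on a double-bonded ring carbon of the shared core. The closest measured evidence is a modest step (a 2.7-fold lower number from compound 2 to compound 3 (0.43 log units; beyond the scatter)) which, read backwards, points to a higher number for compound 4. However, its methylsulfonyl group sits elsewhere on the phenyl ring than in compound 2, and no measured pair shows what that placement does. In this assay a modest rise is therefore expected (a 2.5-fold higher number from compound 3 to compound 4 (0.40 log units; beyond the scatter)) with real uncertainty. For compound 4 the expected value is 25 nM (estimated range 6 nM to 100 nM).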

Compound 4, half-maximal inhibitory concentration: 4.3 nM
Compound 4: middle estimate off by 5.8-fold (0.76 log units), on the high side; measured number outside the range, below it.
By their numbers in this assay, from the lowest: compound 1; then compound 4; then compound 3; then compound 2.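

In this assay, moving the methylsulfonyl group to give 3-(methylsulfonyl)phenyl in place of 4-(methylsulfonyl)phenyl produces a 6.3-fold lower number from compound 2 to compound 4 (0.80 log units; beyond the scatter), so its placement on the phenyl ring matters at this position. Replacing 4-cyanophenyl with 3-(methylsulfonyl)phenyl gives a 2.3-fold lower number from compound 3 to compound 4 (0.37 log units; beyond the scatter), so a methylsulfonyl compound now has the lower number, unlike in the earlier comparison of the nitrile with 4-(methylsulfonyl)phenyl. Nothing measured here explains either step. From the compounds shown here alone, whether a nitrile would respond in the same way if moved on the phenyl ring remains open. So does the effect of an amine or a carboxylic acid in place of the methylsulfonyl group.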